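A few compounds are considered here, and "the series" means these few. Any claim that something is new, unique, unknown or untested is made for them only; others in the source may bear on it.

Of the compounds shown here, two built on a shared core have been measured in a functional assay on RAW264.7 cells (Mus musculus) for inhibition, read by Griess assay, with stated times of 2 h and 24 h; a higher number here means a weaker inhibitor, a lower number a stronger inhibitor. Compound 1 `COc1ccc([C@@H]2CC(=O)c3c(O)cc(OCc4cn(Cc5cccc(C(F)(F)F)c5)nn4)cc3O2)cc1O` gives 19900 nM. Compound 2 `COc1ccc([C@@H]2CC(=O)c3c(O)cc(OCc4cn(C5CCCC5)nn4)cc3O2)cc1O` gives 10500 nM. Within the data shown here, of these two numbers compound 2 has the lower one, yet the only step between them, a 1.9-fold lower number from compound 1 to compound 2 (0.28 log units; within the scatter), stays within the scatter, so neither compound can be called the stronger inhibitor on this evidence. Compound 3 `COc1ccc([C@@H]2CC(=O)c3c(O)cc(OCc4cn(Cc5cccc(Cl)c5)nn4)cc3O2)cc1O` has not yet been measured. It differs from compound 2 in a single place: 3-chlorobenzyl in place of cyclopentyl on an aromatic nitrogen. Among the measured compounds shown here, the one measured step that bears on this change is a 1.9-fold lower number from compound 1 to compound 2 (0.28 log units; within the scatter), which exchanged 3-(trifluoromethyl)benzyl for cyclopentyl on the aromatic nitrogen; compound 3 puts a benzyl group back in that place, now 3-chlorobenzyl instead of cyclopentyl. A change of about the same small size in the opposite direction is therefore expected, giving a number close to that of compound 1 and still within the scatter of compound 2. The estimate for compound 3 in this assay is 15000 nM, with a range from 6000 nM to 40000 nM, which means an expected step of a 1.4-fold higher number from compound 2 to compound 3 (0.15 log units; within the scatter).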

Compound 3, half-maximal inhibitory concentration: 18200 nM
Compound 3: middle estimate off by 1.2-fold (0.08 log units), on the low side; measured number inside the range.
By their numbers in this assay, from the lowest: compounds 2, 3 and 1 (each within the scatter of the next).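

In this assay, a benzyl group and a cyclopentyl group on the aromatic nitrogen can now be compared a second time, and 3-chlorobenzyl in place of cyclopentyl gives a 1.7-fold higher number from compound 2 to compound 3 (0.24 log units; within the scatter), so this change too cannot be read as a real difference. The new compound also allows the first comparison within the benzyl group itself, where chloro in place of trifluoromethyl on an aromatic carbon gives a 1.1-fold lower number from compound 1 to compound 3 (0.04 log units; within the scatter), again with no difference that can be read. Taken together, these three compounds show that neither the exchange of the whole group on this nitrogen nor the exchange of the substituent on its benzyl ring separates one compound from another in this assay. No separate measurement is available that bears on this result.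

From the compounds shown here alone, whether any group on this nitrogen can move the number beyond the scatter remains open, for instance an amine, a carboxylic acid or a longer chain. The plain benzyl group, with no substituent on its ring, is also absent from these compounds, so the effect of having a chloro or trifluoromethyl substituent at all cannot be judged.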